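Dichloro to difluoro on the benzyl group of compound 2

This account rests on a few compounds, and the source may have more. Where it says the series, first, only, none or still open, it means among the compounds named here.

Compound 1 `Cc1c(Cc2c(F)cccc2F)nc(SCc2cccnc2)[nH]c1=O`, which carries 2,6-difluorobenzyl, gives > 70000 nM in an ADME assay on MT4 cells (Homo sapiens) for cytotoxicity, read by MTT assay (on this read-out higher numbers stand for lower toxicity in this test and lower numbers for higher toxicity in this test), and this is a limit. Compound 2 `Cc1c(Cc2c(Cl)cccc2Cl)nc(SCC(=O)c2ccccc2)[nH]c1=O` gives > 60000 nM, also a limit, so its standing in this assay rests on no exact number. Compound 3 `Cc1c(Cc2c(F)cccc2F)nc(SCC(=O)c2ccccc2)[nH]c1=O` has 2,6-difluorophenyl in place of 2,6-dichlorophenyl on a saturated chain carbon bound to an aromatic carbon. For the measured compounds named here, no measured step gives the size of this change, and nothing beyond the scatter is expected. The expected change is a step that the limit leaves unreadable from compound 2 to compound 3. Compound 3 is estimated at 70000 nM, within an expected range of 25000 nM to 200000 nM.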

Compound 3, half-maximal cytotoxic concentration: 65000 nM
Compound 3: middle estimate off by 1.1-fold (0.03 log units), on the high side, within the range that was stated.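

In this assay compound 3 is the only compound shown with an exact value, so 2,6-difluorobenzyl with the benzoyl chain now stands on a number and not on a limit. The step for 2,6-difluorophenyl in place of 2,6-dichlorophenyl cannot be read: the limit of > 60000 nM in this assay, at which 1 of the 3 values shown sits.
Benzoyl in place of pyridin-3-yl on a saturated chain carbon bound to a sulfur gives an at least 1.0-fold lower number from compound 1 to compound 3 (0.03 log units; that floor lies within the scatter), so this change shows no order.

Still open, going by these compounds, is how far the read-out would move with an amine or a carboxylic acid in place of benzoyl. The two benzyl groups also remain without a comparison on exact numbers.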